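The source may report more compounds than this note shows. Statements on the series, on what has been measured and on what is new or still open speak of the compounds shown alone.

In a functional assay on HeLa cells (Homo sapiens) for inhibition, read by MTT assay, with a stated time of 48 h (a lower number here means a stronger inhibitor, a higher number a weaker inhibitor), compound 1 (`COc1cc(/C=C/C(=O)NO)ccc1OCC(=O)Nc1ccccc1F`) gives 11100 nM, the lowest of the three numbers measured. Compound 2 (`COc1cc(/C=C/C(=O)Nc2ccccc2N)ccc1OCC(=O)Nc1cccc(F)c1`) gives 28100 nM, and compound 3 (`COc1cc(/C=C/C(=O)Nc2ccccc2N)ccc1OCC(=O)Nc1ccc(Cl)c(Cl)c1`) gives 72100 nM. Compound 4 (`COc1cc(/C=C/C(=O)NO)ccc1OCC(=O)Nc1cccc(F)c1`) differs from compound 1 by one change: 3-fluorophenyl in place of 2-fluorophenyl on an amide-type nitrogen. Within the data shown here, no measured pair makes this exchange. Among the measured compounds shown here, the only measured step at this place is a 2.6-fold higher number from compound 2 to compound 3 (0.41 log units; beyond the scatter), a modest one, from 3-fluorophenyl to 3,4-dichlorophenyl, with the rest of those compounds differing from compound 1. A step in this assay no larger than that one is therefore expected, with no clear direction. The expected change is a 1.1-fold higher number from compound 1 to compound 4 (0.03 log units; within the scatter), an estimated step within the scatter. For compound 4, the estimated value is 12000 nM, with an expected range of 5000 nM to 30000 nM.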

Compound 4, half-maximal inhibitory concentration: 34500 nM
Beside the measured number, compound 4's estimate is 2.9-fold (0.46 log units) below it, outside the stated range (above it).
By their numbers in this assay, from the lowest: compound 1; then compounds 2 and 4 (each within the scatter of the next); then compound 3.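

In this assay, 3-fluorophenyl in place of 2-fluorophenyl on an amide-type nitrogen gives a 3.1-fold higher number from compound 1 to compound 4 (0.49 log units; beyond the scatter) with the same heavy atoms, so the place of the fluorine on this ring alone changes the number. With 3-fluorophenyl kept, hydroxy in place of 2-aminophenyl gives a 1.2-fold higher number from compound 2 to compound 4 (0.09 log units; within the scatter) and so does not separate these two compounds.

From the compounds shown here alone, how 4-fluorophenyl or 2-chlorophenyl on that nitrogen would compare with compound 1 and compound 4 remains open. Nothing shown here accounts for the difference between compound 1 and compound 4.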